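From Bromo to Diethylamino on a Shared Chalcone Core

The source may report more compounds than this note shows. Statements on the series, on what has been measured and on what is new or still open speak of the compounds shown alone.

Of the compounds shown here, three built on one core have been measured in a functional assay on HT-29 cells (Homo sapiens) for antiproliferative activity, read by MTT assay, with a stated time of 24 h; on this read-out higher numbers stand for weaker inhibition and lower numbers for stronger inhibition. Compound 1 `COc1cccc(/C=C/C(=O)c2ccc(OC)c3c2OC(C)(C)C=C3)c1` gives only a limit, > 10000 nM. Compound 2 `COc1ccc(/C=C/C(=O)c2ccc(OC)c3c2OC(C)(C)C=C3)c(F)c1` likewise gives only a limit, > 10000 nM. Compound 3 `COc1ccc(C(=O)/C=C/c2ccc(Br)cc2)c2c1C=CC(C)(C)O2` also gives only a limit, > 10000 nM. All three sit together at the limit of > 10000 nM in this assay, at which 3 of the 3 values shown sit, so compound 3 cannot be placed above or below its neighbours. The three steps among them, a step that the two limits leave unreadable from compound 1 to compound 2, a step that the two limits leave unreadable from compound 1 to compound 3 and a step that the two limits leave unreadable from compound 2 to compound 3, are unreadable for the same reason and say nothing about how the aryl ring on the double-bonded chain carbon governs potency.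

Compound 4 `CCN(CC)c1ccc(/C=C/C(=O)c2ccc(OC)c3c2OC(C)(C)C=C3)cc1` differs from compound 3 by diethylamino in place of bromo on an aromatic carbon. Going by the values given here, no measured step bears on this change, since every comparison at hand is capped by the limit. Compound 4 is therefore estimated at 7000 nM, within 800 nM to 30000 nM, and the expected step of an at least 1.4-fold lower number from compound 3 to compound 4 (0.15 log units; that floor lies within the scatter) is uncertain in direction, with a real chance that this assay again reports only a limit.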

Compound 4, half-maximal inhibitory concentration: 550 nM
The estimate for compound 4 lay 13-fold (1.10 log units) above the measured number, outside the stated range (below it).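

Going by these compounds alone, at this position, on an aromatic carbon para to a large group, diethylamino in place of bromo gives the first readable number in this assay, with an at least 18-fold lower number from compound 3 to compound 4 (1.25 log units; beyond the scatter). Compound 3 has only a limit, so this step sets a floor and not an exact size. The earlier steps could not be read, and compound 4 alone moves off the shared ceiling: the limit of > 10000 nM in this assay, at which 3 of the 4 values shown sit.

The compounds shown leave open whether the diethylamino group itself matters or another amine on this carbon, such as dimethylamino, pyrrolidine or morpholine, would give a similar number. Within the data shown here, with only one readable value, they also leave open whether the same group would lower the number when placed on the 3-methoxyphenyl ring of compound 1 or the 2-fluoro-4-methoxyphenyl ring of compound 2.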